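This account rests on a few compounds, and the source may have more. Where it says the series, first, only, none or still open, it means among the compounds named here.

Of the compounds shown here, three of a shared core have been measured in a functional assay on MGC-803 cells (Homo sapiens) for cytotoxicity, read by MTT assay, with a stated time of 2 days; a lower number here means a stronger inhibitor, a higher number a weaker inhibitor. Compound 1 `O=[N+]([O-])c1ccc2c(c1)/C(=N\O)C(c1c[nH]c3ccc([N+](=O)[O-])cc13)=N2` gives 10800 nM, compound 2 `c1ccc(CO/N=C2/C(c3c[nH]c4ccccc34)=Nc3ccccc32)cc1` gives 15400 nM, and compound 3 `N#Cc1ccc2c(c1)/C(=N\OCc1ccccc1)C(c1c[nH]c3ccc(C#N)cc13)=N2` gives 15500 nM. Compound 2 therefore stands among numbers that do not differ from one another beyond the usual scatter, its value sitting close to that of compound 3 and also within the scatter of compound 1. Compound 4 `Cc1ccc(CO/N=C2/C(c3c[nH]c4ccccc34)=Nc3ccccc32)cc1` differs from compound 2 by a single change: methyl in place of hydrogen on an aromatic carbon, that is, a methyl in place of hydrogen on an aromatic carbon, or benzyloxy to (4-methylbenzyl)oxy. Among the measured compounds shown here, no step between measured compounds shows what such a change does here, so compound 4 is expected to stay within the scatter of compound 2, and the step from compound 2 to compound 4 is estimated at a 1.2-fold lower number from compound 2 to compound 4 (0.07 log units; within the scatter). For compound 4 the expected value in this assay is 13000 nM, with a range from 5000 nM to 35000 nM.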

Compound 4, half-maximal inhibitory concentration: 22800 nM
Estimate against measurement, compound 4: 1.8-fold (0.24 log units) below, within the range that was stated.
By their numbers in this assay, from the lowest: compounds 1, 2, 3 and 4 (each within the scatter of the next, the first and the last beyond it).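

Going from benzyloxy to (4-methylbenzyl)oxy gives a 1.5-fold higher number from compound 2 to compound 4 (0.17 log units; within the scatter) in this assay, the first single change that can be read among these compounds. A methyl on this aromatic carbon, para to a large group, therefore leaves the number within the scatter. Nothing shown offers a reason for this result. Still open, as far as these compounds go, is whether an amine, a carboxylic acid or a methoxy group in the same place would move the number beyond the scatter. Also open, from the compounds shown here alone, is whether the same methyl would give a like step on compound 3, with its nitrile groups.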